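The source may hold more compounds than are shown below. What is called first, only, known or untested is meant among the compounds shown, and "the series" means these compounds.

Measured compounds:
compound 1, `COc1ccc(NC(=O)c2nc(-c3cc(OC)c(OC)c(OC)c3)n(-c3ccc(OC)cc3)n2)cc1`: 67%
compound 2, `COc1ccc(-n2nc(C(=O)Nc3cccc(F)c3)nc2-c2cc(OC)c(OC)c(OC)c2)cc1`: 72%

In a functional assay on the whole organism for inhibition, with Rattus norvegicus as the target, read by paw edema, with stated times of 30 min and 3 h, at a dose of 0.28 mmol/kg by the oral route (a lower number here means less inhibition, a higher number more inhibition at the dose given (going by the name of the read-out)), compound 1 gives 67%, and compound 2 gives 72%. Compound 2 thus carries the larger of the two numbers, but the step of a number 5 percentage points higher from compound 1 to compound 2 (within the scatter) is within the scatter, so the two compounds cannot be told apart on these results.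

Compound 3, `COc1ccc(-n2nc(C(=O)Nc3ccc(C(=O)O)cc3)nc2-c2cc(OC)c(OC)c(OC)c2)cc1`, is the next compound. It differs from compound 2 in one place: 4-carboxyphenyl in place of 3-fluorophenyl on an amide-type nitrogen. Within the data shown here, the only measured step that bears on this is the one from compound 1 to compound 2, which also exchanged the group on the amide-type nitrogen, and it amounted to a number 5 percentage points higher from compound 1 to compound 2 (within the scatter), no change beyond the scatter. Among the measured compounds shown here, no measured step brings in a 4-carboxyphenyl group, so there is nothing to show whether this exchange behaves like the earlier one.

On that basis, the step of a number 7 percentage points lower from compound 2 to compound 3 (within the scatter) is expected to stay within the scatter, with no clear direction. Compound 3 is therefore estimated to give 65% in this assay , with a range from 40% to 85%.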

Compound 3, a percentage reported as inhibition, in the whole organism at one dose (the size of the read-out at that dose, not a potency): 74%
Compound 3: middle estimate off by 9 percentage points, on the low side, and the stated range covers the measured number.
By their numbers in this assay, from the lowest: compounds 1, 2 and 3 (each within the scatter of the next).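

In this assay, the amide-type nitrogen has now carried three different aromatic groups, and the exchange of 3-fluorophenyl for 4-carboxyphenyl amounts to a number 2 percentage points higher from compound 2 to compound 3 (within the scatter), while carboxy in place of methoxy on an aromatic carbon amounts to a number 7 percentage points higher from compound 1 to compound 3 (within the scatter). This position therefore takes a group with more heavy atoms than 3-fluorophenyl, and with a hydrogen-bond donor and acceptor that 3-fluorophenyl lacks, without any listed step leaving the scatter, so the three compounds cannot be ranked against one another. Nothing available explains why the read-out stays within the scatter across these groups.

The compounds shown leave open whether the same holds for an amine in place of the carboxy group, or for a benzyl group, with its extra carbon, on the amide-type nitrogen. Because each percentage describes the size of the effect at one dose and is not a potency, they also leave open whether these compounds would separate at other doses.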